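The compounds below may be only part of what the source reports. "The series", "measured", "known", "first", "only" and "open" are said of these compounds alone.

Series notes. Compound 1 `O=C1CCCC/C1=C\c1ccc(OC(=O)c2ccc(Cl)cc2)cc1` gives 38000 nM in a functional assay on MOLT-4 cells (Homo sapiens); on this read-out lower numbers stand for stronger inhibition and higher numbers for weaker inhibition. Compound 2 `COc1ccc(C(=O)Oc2ccc(/C=C3\CCCCC3=O)cc2)cc1` gives 34000 nM in this assay; the step of a 1.1-fold lower number from compound 1 to compound 2 (0.05 log units; within the scatter) corresponds to methoxy in place of chloro on an aromatic carbon. Compound 3 `CN(C)CC1CCC/C(=C\c2ccc(OC(=O)c3ccc(Cl)cc3)cc2)C1=O` gives 5110 nM in this assay, the lowest number of the three; the step of a 7.4-fold lower number from compound 1 to compound 3 (0.87 log units; beyond the scatter) corresponds to (dimethylamino)methyl in place of hydrogen on a saturated ring carbon, which is also how the core of compound 3 differs from the core of compound 1. Compound 4 `COc1ccc(C(=O)Oc2ccc(/C=C3\CCCC(CN(C)C)C3=O)cc2)cc1` has not yet been measured in this assay. Compound 4 differs from compound 3 by methoxy in place of chloro on an aromatic carbon, the same change, at the same place, as that between compound 1 and compound 2. For compound 4 the step of a 1.1-fold lower number from compound 3 to compound 4 (0.03 log units; within the scatter) is expected, resting on the earlier occurrence of this change, because a 1.1-fold lower number from compound 1 to compound 2 (0.05 log units; within the scatter) stayed within the scatter. Compound 4 is therefore estimated at 4800 nM in this assay, expected between 2000 nM and 11000 nM.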

Compound 4, half-maximal inhibitory concentration: 2360 nM
Compound 4: middle estimate off by 2.0-fold (0.31 log units), on the high side; the measured number falls inside the stated range.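

Methoxy in place of chloro on an aromatic carbon gives a 2.2-fold lower number from compound 3 to compound 4 (0.34 log units; beyond the scatter) in this assay, and the gap to its earlier occurrence stays within the scatter: the same change on two cores in this assay, a 1.1-fold lower number (0.05 log units; within the scatter) from compound 1 to compound 2 and a 2.2-fold lower number (0.34 log units; beyond the scatter) from compound 3 to compound 4, 1.9-fold (0.29 log units) apart, within the scatter of two such steps. Adding the (dimethylamino)methyl group gives a 14-fold lower number from compound 2 to compound 4 (1.16 log units; beyond the scatter), again in line with its earlier occurrence: the same change on two cores in this assay, a 7.4-fold lower number (0.87 log units; beyond the scatter) from compound 1 to compound 3 and a 14-fold lower number (1.16 log units; beyond the scatter) from compound 2 to compound 4, 1.9-fold (0.29 log units) apart, within the scatter of two such steps. Each change therefore carries across the two cores here without a detectable difference in size, but two pairs cannot show that this holds on other cores or for other groups.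

On these data alone, it remains open whether a piperidine or morpholine would serve in place of the dimethylamino group, or how a longer chain to the amine would read. The 4-chlorophenyl and 4-methoxyphenyl groups also leave open how a nitrile or a hydroxyl would read at that place.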